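Replacing the methoxy of compound 1 with hydrogen

The source may report more compounds than this note shows. Statements on the series, on what has been measured and on what is new or still open speak of the compounds shown alone.

Measured in a functional assay on SW620/5-FU cells (Homo sapiens) for cytotoxicity, read by MTT assay, with a stated time of 48 h, in the presence of a further agent that is not named here; a higher number here means that more compound is needed for the effect, a lower number that less compound is needed:
compound 1 `COc1ccc(-c2cc(NNC(=O)Nc3cc(Cl)nc(Cl)c3)nc3c2cnn3C)cc1`: 18500 nM
compound 2 `COc1ccc(-c2cc(NNC(=O)Nc3cc(Cl)nc(OC(C)C)c3)nc3c2cnn3C)cc1`: 47100 nM
compound 3 `COc1ccc(-c2cc(NNC(=O)Nc3cc(Cl)nc(Cl)c3)nc3c2c(C)nn3C)cc1`: 9700 nM

Within the data shown here, compound 1 stands within the scatter of compound 3 and clear of compound 2, the only one of the pair to differ beyond the scatter. Compound 4 `Cn1ncc2c(-c3ccccc3)cc(NNC(=O)Nc3cc(Cl)nc(Cl)c3)nc21` has hydrogen in place of methoxy on an aromatic carbon, that is 4-methoxyphenyl to phenyl. Among the measured compounds shown here, no measured step touches this group, so the steps give only a scale for single changes: a 2.5-fold higher number from compound 1 to compound 2 (0.41 log units; beyond the scatter) and a 1.9-fold lower number from compound 1 to compound 3 (0.28 log units; within the scatter). Going by these compounds, with that scale, no step beyond the scatter is expected in this assay, and the direction stays open. The estimated change is a 1.1-fold higher number from compound 1 to compound 4 (0.03 log units; within the scatter). Compound 4 is expected at 20000 nM, with an estimated range of 8000 nM to 50000 nM.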

Compound 4, half-maximal effective concentration: 76900 nM
Beside the measured number, compound 4's estimate is 3.8-fold (0.58 log units) below it, outside the stated range (above it).
By their numbers in this assay, from the lowest: compounds 3 and 1 (each within the scatter of the next); then compounds 2 and 4 (each within the scatter of the next).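

In this assay the change from 4-methoxyphenyl to phenyl gives a 4.2-fold higher number from compound 1 to compound 4 (0.62 log units; beyond the scatter) and so shows that this position is not silent: the step lies beyond the scatter and runs towards a higher number. For this single pair, methoxy goes with less compound needed than hydrogen. Nothing available explains the step.

Going by these compounds, whether a hydroxyl, an amine or a longer chain such as ethoxy at this place would match methoxy stays open. So does whether the same step would hold alongside the changes in compound 2 and compound 3.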